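A few compounds are considered here, and "the series" means these few. Any claim that something is new, unique, unknown or untested is made for them only; others in the source may bear on it.

Compound 3 `CC1=CCC[C@H]2[C@](C)(CC3=CC(=O)C=C(N[C@@H](C(=O)O)C(C)C)C3=O)[C@@H](C)CC[C@]12C` and compound 1 `CC1=CCC[C@H]2[C@](C)(CC3=CC(=O)C=C(NCC(=O)O)C3=O)[C@@H](C)CC[C@]12C` share one core, while compound 2 `CC(C)C[C@H](NC1=CC(=O)C=C(C(C)(C)C)C1=O)C(=O)O` is built on a different one; the difference between the two cores is not broken down here. In a functional assay on MDA-MB-453 cells (Homo sapiens) for cytotoxicity, read by MTT assay, with a stated time of 72 h (a higher number here means a weaker inhibitor, a lower number a stronger inhibitor), compound 3 gives 8010 nM, and compound 1 gives 5840 nM. The step from compound 3 to compound 1 is hydrogen in place of isopropyl on a saturated chain carbon bound to an amine nitrogen and a carbonyl carbon, and it brought a 1.4-fold lower number from compound 3 to compound 1 (0.14 log units; within the scatter). In this assay compound 2 gives 84900 nM, the highest number of the three measured. Compound 4 `C[C@H](NC1=CC(=O)C=C(C(C)(C)C)C1=O)C(=O)O` is not yet measured; it differs from compound 2 by hydrogen in place of isopropyl on a saturated chain carbon, two bonds along the chain from an amine nitrogen and a carbonyl carbon. This is the same kind of change as from compound 3 to compound 1, though not the same change. There the isopropyl leaves a carbon bound to the amine nitrogen and carbonyl carbon; here it leaves a carbon two bonds along the chain from them. Resting on the step from compound 3 to compound 1 a 1.4-fold lower number from compound 3 to compound 1 (0.14 log units; within the scatter), compound 4 is expected to show a 1.2-fold lower number from compound 2 to compound 4 (0.08 log units; within the scatter). Compound 4 is thus estimated at 70000 nM, with a range from 30000 nM to 200000 nM.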

Compound 4, half-maximal inhibitory concentration: 112000 nM
Estimate against measurement, compound 4: 1.6-fold (0.20 log units) below; low and high end bracket the measured number.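

In this assay the new step reads a 1.3-fold higher number from compound 2 to compound 4 (0.12 log units; within the scatter) and so lies within the scatter, which means that compound 2 and compound 4 cannot be told apart in this read-out. Set beside the earlier step, the change gives no difference that can be told apart between the two cores: the same change on two cores in this assay, a 1.4-fold lower number (0.14 log units; within the scatter) from compound 3 to compound 1 and a 1.3-fold higher number (0.12 log units; within the scatter) from compound 2 to compound 4, 1.8-fold (0.26 log units) apart, within the scatter of two such steps. This shows that the exchange of isopropyl for hydrogen left the number within the scatter on both cores, but it rests on a single pair per core, with the isopropyl leaving a different place on the chain in each pair, and so it does not show that the change would carry to any further core.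

The compounds shown leave open whether a longer chain or a phenyl ring on the same chain carbon would move the number beyond the scatter on either core. They also leave open what an ester or an amide in place of the carboxylic acid would do.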